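The source may hold more compounds than are shown below. What is called first, only, known or untested is meant among the compounds shown, and "the series" means these compounds.

In a functional assay on MCF7 cells (Homo sapiens) for cytotoxicity, read by MTT assay, with a stated time of 48 h (a lower number here means a stronger inhibitor, a higher number a weaker inhibitor), compound 2 (`CC(C)=CCC/C(C)=C/CC/C(C)=C/CC[C@@H]1[C@@]2(C)C/C(=C\c3ccc(OCc4cn(-c5ccccc5C#N)nn4)cc3)C(=O)C(C)(C)[C@@H]2CC[C@@]1(C)O`) gives 29900 nM and compound 1 (`CC(C)=CCC/C(C)=C/CC/C(C)=C/CC[C@@H]1[C@@]2(C)C/C(=C\c3ccc(OCc4cn(-c5ccc(F)cc5)nn4)cc3)C(=O)C(C)(C)[C@@H]2CC[C@@]1(C)O`) gives 42000 nM on the same core, so these two numbers sit within the usual scatter of each other and neither can be ranked ahead. Compound 3 (`CC(C)=CCC/C(C)=C/CC/C(C)=C/CC[C@@H]1[C@@]2(C)C/C(=C\c3ccc(OCc4cn(-c5ccncc5)nn4)cc3)C(=O)C(C)(C)[C@@H]2CC[C@@]1(C)O`) carries pyridin-4-yl in place of 2-cyanophenyl on an aromatic nitrogen. Within the data shown here, one measured step bears on this change, at that same nitrogen: a 1.4-fold lower number from compound 1 to compound 2 (0.15 log units; within the scatter) with 2-cyanophenyl in place of 4-fluorophenyl. Among the measured compounds shown here, exchanging one ring there for another has thus far stayed within the scatter, although this rests on a single pair and no pyridin-4-yl compound has yet been measured. The expected step is therefore a 1.2-fold higher number from compound 2 to compound 3 (0.07 log units; within the scatter) and nothing beyond the scatter is expected. Compound 3 is estimated at 35000 nM with an expected range of 15000 nM to 75000 nM once tested.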

Compound 3, half-maximal inhibitory concentration: 37500 nM
Beside the measured number, compound 3's estimate is 1.1-fold (0.03 log units) below it; the measured number falls inside the stated range.
By their numbers in this assay, from the lowest: compounds 2, 3 and 1 (each within the scatter of the next).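

In this assay, a third ring on the aromatic nitrogen again leaves the number almost unchanged: a 1.3-fold higher number from compound 2 to compound 3 (0.10 log units; within the scatter) and a 1.1-fold lower number from compound 1 to compound 3 (0.05 log units; within the scatter). Pyridin-4-yl has a nitrogen in its ring and no nitrile, yet compounds 1, 2 and 3 all lie within the scatter of one another and cannot be ranked. At this position, a six-membered aromatic ring of carbon only and one with a hetero atom have so far given matching results, and no supporting data explain this.

Going by these compounds, all three groups here are six-membered aromatic rings, so it remains open whether a group of another kind, such as a longer alkyl chain ending in an amine or a carboxylic acid, would shift the number beyond the scatter.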